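The source may hold more compounds than are shown below. What is called first, only, known or untested is meant among the compounds shown, and "the series" means these compounds.

Compound 1, `CCOC(=O)[C@@H]1CCCN(S(=O)(=O)c2ccc(S(=O)(=O)N(CC)C(C)C)cc2)C1`: 1200 nM
Compound 2, `CCN(CC)S(=O)(=O)c1ccc(S(=O)(=O)N2CCC[C@@H](C(=O)N3CCN(C(=O)OC(C)(C)C)CC3)C2)cc1`: 10 nM
Compound 3, `CCOC(=O)[C@@H]1CCCN(S(=O)(=O)c2cccc(S(=O)(=O)N(CC)CC)c2)C1`: limit, > 10000 nM

In a functional assay on MIA PaCa-2 cells (Homo sapiens) for inhibition, read by MTT assay, with a stated time of 3 days (on this read-out lower numbers stand for stronger inhibition and higher numbers for weaker inhibition), compound 1 gives 1200 nM, the higher of the two numbers seen. Compound 2 gives 10 nM, a gap beyond the scatter of repeated measurements. Compound 3 reaches only the limit of this assay, > 10000 nM, so no number is known for it.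

Compound 4, `CCOC(=O)[C@@H]1CCCN(S(=O)(=O)c2ccc(C(=O)N(CC)CC)cc2)C1`, differs from compound 1 in one place: diethylcarbamoyl in place of ethyl(isopropyl)sulfamoyl on an aromatic carbon. Going by the values given here, no pair of measured compounds shows what this change does, so any expectation rests on compound 1 alone. The step from compound 1 to compound 4 is expected to be a modest weakening, a 2.1-fold higher number from compound 1 to compound 4 (0.32 log units; beyond the scatter), within or just beyond the scatter. Compound 4 is therefore estimated at 2500 nM, between 800 nM and 8000 nM.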

Compound 4, half-maximal inhibitory concentration: 100 nM
Estimate against measurement, compound 4: 25-fold (1.40 log units) above; the whole stated range lies above it.
By their numbers in this assay, from the lowest: compound 2; then compound 4; then compound 1. At a limit, above all of these: compound 3.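

In this assay, diethylcarbamoyl in place of ethyl(isopropyl)sulfamoyl gives a 12-fold lower number from compound 1 to compound 4 (1.08 log units; beyond the scatter), a large gain. A sulfamoyl group is therefore not needed on this aromatic carbon for a low number, at least in this one pair. Nothing measured here explains why the number falls.

Going by these compounds, it remains open how a simple amine or a carboxylic acid would fare at this place. On these data alone, it is also open whether the same swap would lower the number of compound 2.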